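Cyano in place of methyl on the five-membered ring

The source may hold more compounds than are shown below. What is called first, only, known or untested is meant among the compounds shown, and "the series" means these compounds.

For the measured compounds named here, compound 1, `O=C(NCc1ccc(OCc2ccccc2)cc1)n1cccn1`, is one of two members measured so far. In an assay on membranes from brain for binding affinity to Fatty-acid amide hydrolase 1 (Mus musculus), read by fluorescence, with stated times of 1 h and 30 min (a higher number here means a weaker inhibitor, a lower number a stronger inhibitor), compound 1 gives 800 nM. Compound 2, `Cc1cnn(C(=O)N2CCCN(Cc3ccc(OCc4ccccc4)cc3)CC2)c1`, shares the outer part of compound 1 but carries a different linker and a methyl on the five-membered aromatic ring with two nitrogens; in this assay compound 2 gives 560 nM. Of the two numbers that of compound 2 is the lower, yet its gap to compound 1 lies within the scatter of repeated measurements, so the two values cannot be told apart. Going by the values given here, no step between measured compounds that differ in a single place is available in this set.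

Compound 3, `N#Cc1cnn(C(=O)N2CCCN(Cc3ccc(OCc4ccccc4)cc3)CC2)c1`, differs from compound 2 in one place: cyano in place of methyl on an aromatic carbon. Among the compounds with values here, no measured pair shows what this exchange does to the read-out, so the expectation rests on the change alone. The expected step of a 3.7-fold lower number from compound 2 to compound 3 (0.57 log units; beyond the scatter) runs toward a lower number and is estimated to exceed the scatter. Compound 3 is expected to give 150 nM in this assay, with a range from 30 nM to 800 nM.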

Compound 3, half-maximal inhibitory concentration: < 10 nM
Compound 3: a limit, no number (the forecaster's own chance of this, stated with the estimate: 5%); middle value at least 15-fold (1.17 log units) away from the limit.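

For the compounds shown here, this is the first single-place step, and it shows that the aromatic carbon two ring bonds from the ring nitrogen is far from indifferent: in this assay, going from 4-methyl-1H-pyrazol-1-yl to 4-cyano-1H-pyrazol-1-yl gives an at least 56-fold lower number from compound 2 to compound 3 (1.74 log units; beyond the scatter), a large step well beyond the scatter. Compound 3 reads < 10 nM, which is a limit of the assay and not a number. The printed step is therefore only a minimum and the full size of the exchange stays unknown, because compound 3 sits at that limit: the limit of < 10 nM in this assay, at which 1 of the 3 values shown sits.

Still open, going by these compounds, is whether this step belongs to the cyano group itself or would also appear with another group on the same aromatic carbon, such as a chloro group or a carboxamide. Going by these compounds alone, also open is whether the exchange carries over to the linker of compound 1, since the only single-place step here has the linker of compound 2 and compound 3 on both sides.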